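This account rests on a few compounds, and the source may have more. Where it says the series, first, only, none or still open, it means among the compounds named here.

Three compounds share the same readout here. Compound 1 `O=C1N(c2cccc(Cl)c2)CCN1C1CN2CCC1CC2` gives 30.9 nM in a functional assay (Cavia porcellus) for antagonist activity at Serotonin 3 (5-HT3) receptor (Homo sapiens); a higher number here means a weaker inhibitor, a lower number a stronger inhibitor. For the measured compounds named here, compound 2 `O=C1N(c2ccccc2)CCN1C1CN2CCC1CC2` gives 2100 nM in this assay, and the single step between them, a 68-fold higher number from compound 1 to compound 2 (1.83 log units; beyond the scatter), is the only step measured so far. Compound 3 `Cc1[nH]cnc1CN1CCN(c2ccccc2)C1=O`, built on a different core, gives 26.9 nM in this assay; this is the lowest of the three numbers, although its gap to compound 1 is within the scatter, while compound 2 stands far higher.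

Compound 4 `Cc1[nH]cnc1CN1CCN(c2cccc([N+](=O)[O-])c2)C1=O` differs from compound 3 by one change, (nitro in place of hydrogen on an aromatic carbon), placed on an aromatic carbon of a six-membered aromatic ring of carbon only, meta to a large group. The measured step that bears on it runs the other way: removing chloro from that ring in compound 1 raised the number sharply, as a 68-fold higher number from compound 1 to compound 2 (1.83 log units; beyond the scatter) shows. That step belongs to another core and another group, so it is a guide, not a rule. A lower number is expected for compound 4 in this assay, around 10 nM, within 2 nM to 50 nM, meaning an expected step of a 2.7-fold lower number from compound 3 to compound 4 (0.43 log units; beyond the scatter).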

Compound 4, antagonist equilibrium constant: 125 nM
Beside the measured number, compound 4's estimate is 13-fold (1.10 log units) below it; the whole stated range lies below it.
By their numbers in this assay, from the lowest: compounds 3 and 1 (each within the scatter of the next); then compound 4; then compound 2.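

In this assay the nitro group on the aromatic ring raises the number (a 4.6-fold higher number from compound 3 to compound 4 (0.67 log units; beyond the scatter)), so adding a group to this ring does not lower the number in every case. For the compounds shown here, this runs against the only earlier step, where taking chloro away on another core raised the number (a 68-fold higher number from compound 1 to compound 2 (1.83 log units; beyond the scatter)); the ring position therefore gives no single direction across these four compounds. No measurement here explains why the nitro group behaves this way.

The two steps differ in both group and core, so the compounds shown leave open which of the two sets the direction. Chloro on the core of compound 3, nitro on the core of compound 1, or another group such as an amine or methoxy at this place would help separate them.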